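The source may report more compounds than this note shows. Statements on the series, on what has been measured and on what is new or still open speak of the compounds shown alone.

Of the compounds shown here, three have so far been measured in an ADME assay on microsomes from liver (Canis lupus familiaris) for metabolic stability, read by LC-MS, using NADPH, with a stated time of 10 min, tested at 0.1 uM; on this read-out higher numbers stand for fast clearance and lower numbers for slow clearance. Compound 1 `O=C(NCCCCc1ccccc1)c1cccc(C2SCC(=O)N2c2cccc(-c3c[nH]nn3)c2)c1` gives 226 mL.min-1.g-1 in this assay. Compound 2 `C#Cc1cc(C(=O)NCCCCc2ccccc2)cc(C2SCC(=O)N2c2ccccc2OC)c1` gives 1750 mL.min-1.g-1, and compound 3 `Cc1ccnc(N2C(=O)CSC2c2cccc(C(=O)NCCCCn3cccn3)c2)c1` gives 41.8 mL.min-1.g-1. Compound 1 therefore stands second highest of the three: compound 3 lies below it by a margin beyond the usual scatter of repeated measurements, and compound 2 lies above it, also beyond the scatter.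

Compound 4 `O=C(NCCCCc1ccccc1)c1cccc(C2SCC(=O)N2c2ccccc2F)c1` has not yet been measured in this assay. It differs from compound 1 in one place: a group of 7 heavy atoms (6 carbon, 1 fluorine; one six-membered aromatic ring of carbon only) in place of a group of 11 heavy atoms (8 carbon, 3 nitrogen; one five-membered aromatic ring with 3 hetero atoms, one six-membered aromatic ring of carbon only), on an amide-type nitrogen in a ring. Among the compounds with values here, no pair of measured compounds shows this same change, so the size of the step cannot be read from a direct neighbour. Among the measured compounds, compound 2, which also carries a six-membered aromatic ring of carbon only on the amide-type nitrogen in a ring, gives 1750 mL.min-1.g-1, whereas compound 3, with more nitrogen in its structure, gives 41.8 mL.min-1.g-1. On that basis compound 4 is expected to clear faster than compound 1, with an estimated 700 mL.min-1.g-1 and a range from 250 mL.min-1.g-1 to 2000 mL.min-1.g-1. The expected step of a 3.1-fold higher number from compound 1 to compound 4 (0.49 log units; beyond the scatter) is an increase beyond the scatter.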

Compound 4, intrinsic clearance in microsomes: 815 mL.min-1.g-1
Beside the measured number, compound 4's estimate is 1.2-fold (0.07 log units) below it; the range from low to high includes it.
By their numbers in this assay, from the lowest: compound 3; then compound 1; then compound 4; then compound 2.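

In this assay, putting 2-fluorophenyl on the amide-type nitrogen in the ring, in place of the larger group of compound 1, gives a 3.6-fold higher number from compound 1 to compound 4 (0.56 log units; beyond the scatter). Within the data shown here, this is the first direct sign that a change at this position alone can move clearance by more than the usual scatter, which no earlier pair could show. No measurement here bears on why the number rises.

The change removes the five-membered aromatic ring and adds a fluorine in a single step, so the compounds shown cannot separate the two. A plain phenyl group on the same nitrogen would help to do that, and a carboxylic acid on that phenyl would show how a different group at this place compares.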